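This account rests on a few compounds, and the source may have more. Where it says the series, first, only, none or still open, it means among the compounds named here.

Of the compounds shown here, three that share one core have been measured in a functional assay on HT-29 cells (Homo sapiens) for cytotoxicity, read by MTT assay, with a stated time of 72 h; on this read-out higher numbers stand for weaker inhibition and lower numbers for stronger inhibition. Compound 1 `COc1ccc(OC)c(/C=N/NC(=O)Nc2ccc(Oc3ccnc(-c4nncn4CCN(C)C)c3)c(F)c2)c1` gives 2070 nM. Compound 2 `CN(C)CCn1cnnc1-c1cc(Oc2ccc(NC(=O)N/N=C/c3ccc(Cl)cc3)cc2F)ccn1` gives 530 nM, and compound 3 `CN(C)CCn1cnnc1-c1cc(Oc2ccc(NC(=O)N/N=C/c3c(O)ccc4ccccc34)cc2F)ccn1` gives 670 nM. Among these three numbers compound 3 stands second highest: its nearest neighbour is compound 2, with a 1.3-fold higher number from compound 2 to compound 3 (0.10 log units; within the scatter), a step within the scatter, while its furthest is compound 1, with a 3.1-fold lower number from compound 1 to compound 3 (0.49 log units; beyond the scatter).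

Compound 4 `CN(C)CCn1cnnc1-c1cc(Oc2ccc(NC(=O)N/N=C/c3ccccc3O[N+](=O)[O-])cc2F)ccn1` has not yet been measured. It differs from compound 3 in one place: 2-(nitrooxy)phenyl in place of 2-hydroxynaphthalen-1-yl on a carbon with a double bond to nitrogen

The measured steps that bear on this are all exchanges of the group on a carbon with a double bond to nitrogen. One such exchange gave a 3.9-fold lower number from compound 1 to compound 2 (0.59 log units; beyond the scatter); another gave a 3.1-fold lower number from compound 1 to compound 3 (0.49 log units; beyond the scatter); a third stayed within the scatter, giving a 1.3-fold higher number from compound 2 to compound 3 (0.10 log units; within the scatter). Two of these three exchanges moved the number only modestly, and one not beyond the scatter, so for compound 4 a step of at most modest size is expected in this assay, with no firm direction. Compound 4 is therefore estimated at 800 nM, within a range from 300 nM to 2500 nM, which means a step of a 1.2-fold higher number from compound 3 to compound 4 (0.08 log units; within the scatter) is expected.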

Compound 4, half-maximal inhibitory concentration: 950 nM
Estimate against measurement, compound 4: 1.2-fold (0.07 log units) below; low and high end bracket the measured number.
By their numbers in this assay, from the lowest: compounds 2, 3 and 4 (each within the scatter of the next); then compound 1.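

In this assay, the 2-(nitrooxy)phenyl group brings one aromatic ring in place of the two of 2-hydroxynaphthalen-1-yl, and no hydrogen-bond donor in place of one, yet the exchange gives a 1.4-fold higher number from compound 3 to compound 4 (0.15 log units; within the scatter), and the exchange with 4-chlorophenyl gives a 1.8-fold higher number from compound 2 to compound 4 (0.25 log units; within the scatter), so among these compounds neither the second ring nor that donor is needed to keep the number at this level. The step against the dimethoxy compound, a 2.2-fold lower number from compound 1 to compound 4 (0.34 log units; beyond the scatter), is smaller than the other two steps from compound 1 but still lies beyond the scatter, so three quite different groups on a carbon with a double bond to nitrogen now sit together, and compound 1 with its 2,5-dimethoxyphenyl group stands apart from them. No measured property of these groups is available to explain this grouping.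

Going by these compounds, whether the nitrooxy group itself contributes anything remains open, as a plain phenyl or a 2-hydroxyphenyl group in the same place would be the direct comparison. It is also unknown whether this tolerance extends to quite different groups, such as an aminophenyl or a carboxyphenyl.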